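Working notes: bromo in place of 2-methoxyphenyl

The source may hold more compounds than are shown below. What is called first, only, known or untested is meant among the compounds shown, and "the series" means these compounds.

- compound 1 `COc1ccccc1-c1cc(/C=C/c2ccc(C(=O)NO)cc2)ccn1` gives 6350 nM as a number
- compound 2 `O=C(NO)c1ccc(/C=C/c2cc(-c3ccc(C(F)(F)F)cc3)ncc2F)cc1` gives > 10000 nM as a limit

Among the measured compounds shown here, in a functional assay on MGC-803 cells (Homo sapiens) for antiproliferative activity, read by CellTiter-Glo, with a stated time of 72 h (on this read-out lower numbers stand for stronger inhibition and higher numbers for weaker inhibition), compound 1 holds the only number. Compound 2 stays at a limit (the limit of > 10000 nM in this assay, at which 1 of the 2 values shown sits). Compound 3 `O=C(NO)c1ccc(/C=C/c2ccnc(Br)c2)cc1` follows from compound 1 by bromo in place of 2-methoxyphenyl on an aromatic carbon and so carries bromo in place of 2-methoxyphenyl on an aromatic carbon. For the measured compounds named here, no measured step speaks to this change, so no shift beyond the scatter is expected in this assay in either direction. The expected change is a 1.3-fold lower number from compound 1 to compound 3 (0.10 log units; within the scatter) and no more. For compound 3 the estimate is 5000 nM as the expected value, within an estimated range of 1500 nM to 15000 nM for now.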

Compound 3, half-maximal inhibitory concentration: > 10000 nM
Compound 3: a limit, no number; the forecaster's own chance of this, stated with the estimate: 30%; at least 2.0-fold (0.30 log units) between middle value and limit.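

In this assay compound 3 stands at a limit, > 10000 nM, and not at a number. Bromo in place of 2-methoxyphenyl on this aromatic carbon, next to the ring nitrogen, gives an at least 1.5-fold higher number from compound 1 to compound 3 (0.19 log units; that floor lies within the scatter), so the change shows no gain, and the true size of the step stays unknown. The limit leaves little room to separate compounds in this small set: the limit of > 10000 nM in this assay, at which 2 of the 3 values shown sit.

Still open, on these data alone, is whether a plain phenyl or an amine on this aromatic carbon would give a measurable number. As far as these compounds go, the part played by the methoxy on the phenyl ring of compound 1 also remains open.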